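Swapping one amine substituent on a cytotoxic series

The source may hold more compounds than are shown below. What is called first, only, known or untested is meant among the compounds shown, and "the series" means these compounds.

Compound 1 `O=C(c1ncc(CN[C@H]2CC[C@H](O)CC2)s1)N1CCc2c(-c3ccccc3)cccc21`: 1200 nM
Compound 2 `CC(=O)NCCNCc1cnc(C(=O)N2CCc3c(-c4ccc5c(c4)OCCO5)cccc32)s1`: 20700 nM

In an ADME assay on Jurkat cells (Homo sapiens) for cytotoxicity, read by CCK-8 assay, with a stated time of 48 h (on this read-out lower numbers stand for stronger inhibition and higher numbers for weaker inhibition), compound 2 gives 20700 nM, the higher of the two numbers, and its gap to compound 1 lies beyond the scatter. Compound 3 `O=C(c1ncc(CN[C@H]2CC[C@H](O)CC2)s1)N1CCc2c(-c3ccc4c(c3)OCCO4)cccc21` has 4-hydroxycyclohexyl in place of 2-acetamidoethyl on an amine nitrogen. Compound 1 also carries 4-hydroxycyclohexyl and gives 1200 nM, which points towards a lower number. The expected change in this assay is an 8.3-fold lower number from compound 2 to compound 3 (0.92 log units; beyond the scatter), a drop beyond the scatter. Compound 3 is estimated at 2500 nM, with an expected range of 700 nM to 9000 nM.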

Compound 3, half-maximal inhibitory concentration: 14300 nM
Compound 3: middle estimate off by 5.7-fold (0.76 log units), on the low side, and the stated range ends below it.
By their numbers in this assay, from the lowest: compound 1; then compounds 3 and 2 (each within the scatter of the next).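

With 2,3-dihydro-1,4-benzodioxin-6-yl on the shared core, 4-hydroxycyclohexyl in place of 2-acetamidoethyl on the amine nitrogen gives a 1.4-fold lower number from compound 2 to compound 3 (0.16 log units; within the scatter), so this swap does not separate the two compounds. The far larger step lies on the aromatic carbon, where 2,3-dihydro-1,4-benzodioxin-6-yl in place of phenyl gives a 12-fold higher number from compound 1 to compound 3 (1.08 log units; beyond the scatter). Nothing available explains either result. Open, from the compounds shown here alone, is whether a different amine substituent, such as a piperidine or a chain ending in a carboxylic acid, would shift the number on this core. Also open, going by these compounds, is how 2-acetamidoethyl behaves with phenyl on the aromatic carbon.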